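Trading a morpholine for an oxane on the sulfonyl

This account rests on a few compounds, and the source may have more. Where it says the series, first, only, none or still open, it means among the compounds named here.

Of the compounds shown here, two measured so far share an amide that links a bicyclic aromatic acid to a benzylamine bearing a sulfonyl group. Compound 1 `O=C(NCc1ccc(S(=O)(=O)N2CCOCC2)cc1)c1cc2ccncc2o1` gives 32 nM in an assay for inhibition of Nicotinamide phosphoribosyltransferase (Homo sapiens), with stated times of 15 min and 30 min; a lower number here means a stronger inhibitor, a higher number a weaker inhibitor. Compound 2 `O=C(NCc1ccc(S(=O)(=O)N2CCOCC2)cc1)c1cc2cnccc2[nH]1` gives 88 nM in this assay. Among the compounds with values here, of these two numbers compound 1 stands lowest, and the only neighbour lies at a 2.8-fold higher number from compound 1 to compound 2 (0.44 log units; beyond the scatter), a change on the carbonyl carbon where one bicyclic core replaces another.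

Compound 3 `O=C(NCc1ccc(S(=O)(=O)C2CCOCC2)cc1)c1cc2ccncc2o1` departs from compound 1 on the far side of the molecule: oxan-4-yl in place of morpholin-4-yl on a sulfonyl sulfur. Within the data shown here, the single measured step concerns the acid-side core and says nothing about the sulfonyl substituent, so no direct guide exists for this exchange. Both groups keep the same ring size and the same acceptor count, and with no evidence either way the sensible expectation is a step within the scatter, perhaps a slight loss. Compound 3 is therefore expected to give about 45 nM, with a likely range from 15 nM to 130 nM. The expected step is a 1.4-fold higher number from compound 1 to compound 3 (0.15 log units; within the scatter).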

Compound 3, half-maximal inhibitory concentration: 47 nM
Compound 3: the middle estimate sits 1.0-fold (0.02 log units) below what was measured; low and high end bracket the measured number.
By their numbers in this assay, from the lowest: compounds 1, 3 and 2 (each within the scatter of the next, the first and the last beyond it).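

In this assay, oxan-4-yl in place of morpholin-4-yl on a sulfonyl sulfur gives a 1.5-fold higher number from compound 1 to compound 3 (0.17 log units; within the scatter). Within the data shown here, this is the first reading at this end of the molecule, as the earlier step touched only the group on the carbonyl carbon, and it shows that a ring nitrogen on the sulfonyl sulfur can give way to a ring carbon with no difference this assay can separate from ordinary scatter. Nothing available here explains why the two groups read alike.

The compounds shown leave open whether the ring oxygen or even the ring itself matters at this position: cyclohexyl or piperidin-1-yl on the sulfonyl sulfur would remove the oxygen but keep a ring, while a methyl group would remove the ring altogether. Also open, on these data alone, is whether the exchange would read the same way on the core of compound 2, as oxan-4-yl appears here only on the core of compound 1.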